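Amino in place of nitro: compound 2 to compound 3

This account rests on a few compounds, and the source may have more. Where it says the series, first, only, none or still open, it means among the compounds named here.

Compound 1 `CNc1nc(Nc2ccc(C)c(N)c2)ncc1C(=O)Nc1cc(NC(=O)c2cccc(C(F)(F)F)c2)ccc1C` gives 14 nM in a functional assay on K562 cells (Homo sapiens) for antiproliferative activity, read by CellTiter-Glo and CCK-8 assay, with a stated time of 72 h; on this read-out higher numbers stand for weaker inhibition of growth and lower numbers for stronger inhibition of growth. Compound 2 `CNc1nc(Nc2ccc(C)c([N+](=O)[O-])c2)ncc1C(=O)Nc1cc(NC(=O)c2ccccc2OC)ccc1C` reaches only the limit of > 10000 nM in this assay, so for compound 2 there is no number, only that limit (the limit of > 10000 nM in this assay, at which 1 of the 2 values shown sits). Compound 3 `CNc1nc(Nc2ccc(C)c(N)c2)ncc1C(=O)Nc1cc(NC(=O)c2ccccc2OC)ccc1C` is compound 2 with amino in place of nitro on an aromatic carbon, the amino that compound 1 also carries. For the measured compounds named here, no measured step covers this change; a large step toward stronger inhibition is expected an at least 50-fold lower number from compound 2 to compound 3 (1.69 log units; beyond the scatter). For compound 3 the expected value is 200 nM, with a range from 20 nM to 3000 nM.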

Compound 3, concentration for 50% growth inhibition: 1980 nM
The estimate for compound 3 lay 9.9-fold (1.00 log units) below the measured number; low and high end bracket the measured number.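

Amino in place of nitro on an aromatic carbon brings compound 3 into the measurable range in this assay, an at least 5.0-fold lower number from compound 2 to compound 3 (0.70 log units; beyond the scatter). From the compounds shown here alone, the true size of this step stays unknown, as compound 2 has only a limit: the limit of > 10000 nM in this assay, at which 1 of the 3 values shown sits. Amino alone does not give a low number: with 2-methoxyphenyl in place of 3-(trifluoromethyl)phenyl on the carbonyl carbon, the series shows a 140-fold higher number from compound 1 to compound 3 (2.15 log units; beyond the scatter).

Still open, going by these compounds, is whether a hydroxyl or a methylamino group could stand in for the amino. Also open, on these data alone, is how nitro behaves alongside 3-(trifluoromethyl)phenyl.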